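Swapping the aryl group on the sulfonyl of compound 1

The source may hold more compounds than are shown below. What is called first, only, known or untested is meant among the compounds shown, and "the series" means these compounds.

Compound 1, with the structure `CC1CCN(c2c(S(=O)(=O)c3ccc(F)cc3)cnc3cc(Cl)ccc23)CC1`, has the higher number of the two measured compounds here. In an assay on isolated protein for displacement of a labelled ligand from metabotropic glutamate receptor 5 (Homo sapiens), with a stated time of 60 min, tested at 1 uM (on this read-out lower numbers stand for less inhibition and higher numbers for more inhibition at the one concentration tested (going by the name of the read-out)), compound 1 gives 91%, the highest of the two numbers. Its nearest neighbour is compound 2, with the structure `O=S(=O)(c1ccc(F)cc1)c1cnc2cc(Cl)ccc2c1N1CCC(CO)CC1`, which in this assay gives 75%. Going by the values given here, the one measured step, a number 16 percentage points lower from compound 1 to compound 2 (beyond the scatter), comes from placing hydroxy in place of hydrogen on a saturated chain carbon bound to a saturated ring carbon.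

Compound 3, with the structure `COc1ccc(S(=O)(=O)c2cnc3cc(Cl)ccc3c2N2CCC(C)CC2)cc1Cl`, has not yet been measured. It differs from compound 1 by 3-chloro-4-methoxyphenyl in place of 4-fluorophenyl on a sulfonyl sulfur. Among the compounds with values here, this change sits on the sulfonyl sulfur, whereas the only measured step concerns the saturated ring on the other side of the shared core, so no measured step bears directly on this change. Without such a step, the expectation can only be that compound 3 stays in the region of compound 1, with a wider range to allow for the untested change; the estimated step is a number 11 percentage points lower from compound 1 to compound 3 (beyond the scatter). Compound 3 is therefore expected to give about 80% in this assay, within a range from 55% to 95%.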

Compound 3, a percentage reported as inhibition, at one concentration (the size of the read-out at that concentration, not a potency): 93%
Estimate against measurement, compound 3: 13 percentage points below, and the stated range covers the measured number.
By their numbers in this assay, from the lowest: compound 2; then compounds 1 and 3 (each within the scatter of the next).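

The sulfonyl sulfur turns out to accept a clear change of aryl group in this assay without a measurable effect: the step to 3-chloro-4-methoxyphenyl, which has more heavy atoms than 4-fluorophenyl and brings one hydrogen-bond acceptor, is a number 2 percentage points higher from compound 1 to compound 3 (within the scatter). Going by these compounds alone, this differs from the one earlier step, on the saturated ring on the other side of the shared core, which is a number 16 percentage points lower from compound 1 to compound 2 (beyond the scatter), so this is the first sign that the aryl group on the sulfonyl sulfur can be replaced while the number stays high. Nothing measured here gives a reason for this lack of change.

Going by these compounds, the swap brings in the chlorine and the methoxy together, so what each does alone stays open, and with both compounds so high at one concentration, a real difference in potency could still lie hidden. On these data alone, it also remains open whether a different kind of group on this aryl ring, such as a carboxylic acid or an amine, would keep the number in the same region.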